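The source may report more compounds than this note shows. Statements on the series, on what has been measured and on what is new or still open speak of the compounds shown alone.

Working notes on the set run in an ADME assay on COS-7 cells (Chlorocebus aethiops) for cytotoxicity, read by MTT assay, with a stated time of 48 h; on this read-out lower numbers stand for stronger inhibition and higher numbers for weaker inhibition. Compound 1 `CCOS(=O)(=O)/C=C/c1ccc(OCc2ccccc2)cc1OCCc1nc(-c2ccccc2)oc1C` returns only a limit of this assay, > 100000 nM, and no number. Compound 2 `CCOS(=O)(=O)/C=C/Cc1cc2ccc(OCCc3nc(-c4ccccc4)oc3C)cc2o1` likewise stops at a limit in this assay, > 100000 nM. Compound 3 `CCCCOS(=O)(=O)/C=C/c1ccc(OCCc2nc(-c3ccccc3)oc2C)cc1` also gives a limit, > 100000 nM. Among the measured compounds shown here, compound 1 thus stands level with the other two measured compounds: all three sit at the limit of > 100000 nM in this assay, at which 3 of the 3 values shown sit, so none can be ordered against another within this assay, and no single-change step between measured compounds exists to draw on. The three measured compounds differ among themselves in more than one place, yet every one of them reaches the same limit.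

The unmeasured compound 4 `COS(=O)(=O)/C=C/c1ccc(OCc2ccccc2)cc1OCCc1nc(-c2ccccc2)oc1C` differs from compound 1 by hydrogen in place of methyl on a saturated chain carbon bound to an oxygen on an unsaturated carbon. Since the three measured compounds all sit at the limit of > 100000 nM in this assay, at which 3 of the 3 values shown sit, across several structural variations, the expectation for this smaller change is the same outcome. Expected is a step that the limit leaves unreadable from compound 1 to compound 4, that is, no shift beyond the usual scatter of this assay. Compound 4 is expected at 150000 nM, within 50000 nM to 500000 nM, and most likely to be reported again only as a limit rather than a number.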

Compound 4, half-maximal inhibitory concentration: > 100000 nM
Compound 4 gave a limit, no number (the forecaster's own chance of this, stated with the estimate: 85%); the middle value is on the limit's open side.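

In this assay compound 4 returns > 100000 nM as a limit, not a number. Compound 1 likewise returns > 100000 nM as a limit. Among the compounds shown here, no step from compound 1 to compound 4 can be read from these two limits. The compounds shown leave open whether any of them differs from another in this read-out, because all remain at one limit: the limit of > 100000 nM in this assay, at which 4 of the 4 values shown sit.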